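Cytotoxicity notes: pyrrolidine to phenyl on the sulfinyl sulfur

The source may report more compounds than this note shows. Statements on the series, on what has been measured and on what is new or still open speak of the compounds shown alone.

The series shares a sulfur core bearing a trifluoromethylthio group on the imine nitrogen. Compound 1 is `O=S(=NSC(F)(F)F)(c1ccccc1)N1CCOCC1`; in a functional assay on HepG2 cells (Homo sapiens) for cytotoxicity, read by MTT assay, with a stated time of 6 h (on this read-out higher numbers stand for weaker inhibition and lower numbers for stronger inhibition), compound 1 is reported as "not determined" (no result reported). Compound 3 is `Cc1ccc(S(=O)(=NSC(F)(F)F)N2CCCC2)cc1`; in this assay compound 3 is reported as "not determined" (no result reported). Compound 2 is `O=S(=NSC(F)(F)F)(c1ccccc1)N1CCCC1`; in this assay compound 2 gives 15 ug/mL. Among the compounds with values here, compound 2 therefore stands as the sole compound of the set with a number in this assay, so there is no measured step to compare it against and no internal pattern to lean on.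

Compound 4 is `O=S(=NSC(F)(F)F)(c1ccccc1)c1ccccc1`. Relative to compound 2 the change is phenyl in place of pyrrolidin-1-yl on a sulfinyl sulfur, so the sulfinyl sulfur now carries two aromatic rings instead of one ring and a saturated nitrogen ring. Within the data shown here, no measured pair reports what such a change does in this assay, so there is no basis for a directed expectation. The step from compound 2 to compound 4 in this assay is expected to be no change at the digits printed from compound 2 to compound 4 (within the scatter), that is, none beyond the usual scatter, with the range kept wide to reflect the lack of a reference step. Compound 4 is accordingly estimated at 15 ug/mL, between 5 ug/mL and 45 ug/mL.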

Compound 4, half-maximal inhibitory concentration: 90 ug/mL
Estimate against measurement, compound 4: 6.0-fold (0.78 log units) below; measured number above the stated range.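

In this assay the group on the sulfinyl sulfur matters: phenyl in place of pyrrolidin-1-yl gives a 6.0-fold higher number from compound 2 to compound 4 (0.78 log units; beyond the scatter), a modest step beyond the scatter and toward weaker inhibition. Within the data shown here, this is the first measured step, so the place on a sulfinyl sulfur whose other neighbours are an aromatic carbon and a sulfonamide nitrogen now has a direction for this one change, with pyrrolidin-1-yl on the side of stronger inhibition and phenyl on the side of weaker inhibition. Nothing available bears on what lies behind this step.

Steps involving compound 1 or compound 3 cannot be read, as neither carries a number, so a single pair is all that supports this direction, and it is unknown whether it would hold with the other groups in the series. Also open, going by these compounds, is whether a piperidine ring or an open-chain dimethylamino group in place of pyrrolidin-1-yl would stay close to compound 2 or move toward compound 4.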